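Swapping the triazole tail of compound 1 for dimethylamino

A few compounds are considered here, and "the series" means these few. Any claim that something is new, unique, unknown or untested is made for them only; others in the source may bear on it.

Compound 1 `Cn1ncc(Cl)c1-c1cc(C(=O)N[C@@H]2CN[C@H](CCn3cncn3)C[C@H]2c2ccc(Cl)c(Cl)c2)oc1Cl` and compound 2 `Cn1ncc(Cl)c1-c1cc(C(=O)N[C@@H]2CN[C@H](CC(N)=O)C[C@H]2c2ccc(Cl)c(Cl)c2)oc1Cl` share one core and differ only in the group carried on the chain attached to a saturated ring carbon. In a functional assay on OVCAR-8 cells (Homo sapiens) for antiproliferative activity (a lower number here means a stronger inhibitor, a higher number a weaker inhibitor), compound 1 gives 1560 nM, the larger of the two numbers, and compound 2 gives 1000 nM; the gap between them is within the scatter. The step of a 1.6-fold lower number from compound 1 to compound 2 (0.19 log units; within the scatter) shows that exchanging that chain end did not shift the number beyond the scatter. Compound 3 `CN(C)CC[C@@H]1C[C@@H](c2ccc(Cl)c(Cl)c2)[C@H](NC(=O)c2cc(-c3c(Cl)cnn3C)c(Cl)o2)CN1` has not yet been measured. Relative to compound 1 the change is dimethylamino in place of 1H-1,2,4-triazol-1-yl on a saturated chain carbon, two bonds along the chain from a saturated ring carbon. For the measured compounds named here, the only measured step that bears on this change is a 1.6-fold lower number from compound 1 to compound 2 (0.19 log units; within the scatter), which altered the same chain and stayed within the scatter. The expected step is therefore a 1.2-fold lower number from compound 1 to compound 3 (0.08 log units; within the scatter), nothing beyond the scatter. Compound 3 is thus estimated at 1300 nM, with a range from 450 nM to 4000 nM.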

Compound 3, half-maximal inhibitory concentration: 1510 nM
Beside the measured number, compound 3's estimate is 1.2-fold (0.07 log units) below it; the range from low to high includes it.
By their numbers in this assay, from the lowest: compounds 2, 3 and 1 (each within the scatter of the next).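

In this assay the step of a 1.0-fold lower number from compound 1 to compound 3 (0.01 log units; within the scatter) shows that the 1H-1,2,4-triazol-1-yl end of this chain can give way to dimethylamino, a group with no ring, without the number moving beyond the scatter. The step of a 1.5-fold higher number from compound 2 to compound 3 (0.18 log units; within the scatter) also stays within the scatter, so the triazole, carbamoyl and dimethylamino chain ends cannot be told apart in this measurement. No evidence is available on what lies behind this sameness.

Still open, going by these compounds, is whether a different chain end, such as a carboxylic acid or a longer chain ending in a piperidine, would move the number beyond the scatter. Also open, on these data alone, is whether a plain ethyl group, with no such end at all, would read the same.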